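A few compounds are considered here, and "the series" means these few. Any claim that something is new, unique, unknown or untested is made for them only; others in the source may bear on it.

Measured compounds:
Compound 1 `Cc1cc(O)c(C2=NN(c3ccc(S(N)(=O)=O)cc3)C(c3ccccc3O)C2)cc1Cl` — in a functional assay on KM12 cells (Homo sapiens) for antiproliferative activity, with a stated time of 48 h (on this read-out lower numbers stand for higher toxicity in this test and higher numbers for lower toxicity in this test), compound 1 gives 6820 nM.
Compound 2 `Cc1cc(O)c(C2=NN(c3ccc(S(N)(=O)=O)cc3)C(/C=C/c3ccccc3)C2)cc1Cl` — in this assay compound 2 gives only a limit, > 100000 nM.

Compound 2 thus stands at the limit of the test (the limit of > 100000 nM in this assay, at which 1 of the 2 values shown sits), whereas compound 1 sits well inside the measured range. Within the data shown here, the single step observed so far is an at least 14-fold higher number from compound 1 to compound 2 (1.16 log units; beyond the scatter). Compound 3 `COc1ccc(C2CC(c3cc(Cl)c(C)cc3O)=NN2c2ccc(S(N)(=O)=O)cc2)cc1OC` differs from compound 2 in one place: 3,4-dimethoxyphenyl in place of 2-phenylethenyl on a saturated ring carbon. This change runs in the opposite sense to the step from compound 1 to compound 2, removing the 2-phenylethenyl group from a saturated ring carbon and placing an aromatic ring there again, as compound 1 has. The step of an at least 14-fold higher number from compound 1 to compound 2 (1.16 log units; beyond the scatter) is therefore the one that bears on it, and a large decrease in this assay is expected, roughly undoing that step, though compound 3 carries a 3,4-dimethoxyphenyl group rather than the 2-hydroxyphenyl group of compound 1. Compound 3 is expected to give 12000 nM, between 3000 nM and 60000 nM. The estimate therefore corresponds to an expected step of an at least 8.3-fold lower number from compound 2 to compound 3 (0.92 log units; beyond the scatter).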

Compound 3, concentration lethal to 50% of the cells: 49200 nM
Beside the measured number, compound 3's estimate is 4.1-fold (0.61 log units) below it, and the stated range covers the measured number.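

At this saturated ring carbon, an aromatic ring alone does not bring back the number of compound 1 in this assay: replacing 2-hydroxyphenyl with 3,4-dimethoxyphenyl gives a 7.2-fold higher number from compound 1 to compound 3 (0.86 log units; beyond the scatter). So the groups on that ring matter, not only the presence of a ring in place of 2-phenylethenyl. From the compounds shown here alone, replacing 2-phenylethenyl with 3,4-dimethoxyphenyl gives an at least 2.0-fold lower number from compound 2 to compound 3 (0.30 log units; that floor lies within the scatter), and the true size of this step stays unknown because its starting value is a limit: the limit of > 100000 nM in this assay, at which 1 of the 3 values shown sits.

The compounds shown do not separate the loss of the hydroxy group from the gain of the two methoxy groups in the step to 3,4-dimethoxyphenyl. Also open, going by these compounds, is how a plain phenyl group or a phenyl ring bearing an amine would read at this carbon.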